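Pyridinyl ether variation and membrane permeability

The source may report more compounds than this note shows. Statements on the series, on what has been measured and on what is new or still open speak of the compounds shown alone.

Measured compounds:
Compound 1 `Cn1c(COc2cccc(C(=O)O)c2)nc2ccc(Oc3ncccc3Cl)cc21` gives 8.1 10^-6 cm/s in an ADME assay for permeability, using PAMPA, with a stated time of 4 h; on this read-out higher numbers stand for higher permeability and lower numbers for lower permeability.
Compound 2 `Cn1c(COc2cccc(C(=O)O)c2)nc2ccc(Oc3ccc(F)cn3)cc21` gives 4.7 10^-6 cm/s in this assay.

Within the data shown here, compound 2 holds the lower of the two numbers, with compound 1 as its only neighbour; the one measured step, a 1.7-fold lower number from compound 1 to compound 2 (0.24 log units; within the scatter), lies within the scatter, so the two compounds cannot be ordered. Compound 3 `Cc1cc(Cl)cnc1Oc1ccc2nc(COc3cccc(C(=O)O)c3)n(C)c2c1` differs from compound 2 in one place: 5-chloro-3-methylpyridin-2-yl in place of 5-fluoropyridin-2-yl on an oxygen on an aromatic ring. Among the measured compounds shown here, the only step that bears on this change is the exchange of substituents on the pyridin-2-yl ring from compound 1 to compound 2, and that step was small. No measurement covers a chloro together with a methyl on this ring, so the expectation rests on that single small step alone. The step of a 1.5-fold higher number from compound 2 to compound 3 (0.17 log units; within the scatter) is therefore expected to stay within the scatter, with a slight lean upward. Compound 3 is estimated at 7 10^-6 cm/s, with a range from 3.5 10^-6 cm/s to 14 10^-6 cm/s.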

Compound 3, apparent permeability: 13.7 10^-6 cm/s
Estimate against measurement, compound 3: 2.0-fold (0.29 log units) below; the range from low to high includes it.
By their numbers in this assay, from the lowest: compounds 2, 1 and 3 (each within the scatter of the next, the first and the last beyond it).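

Among the groups on the oxygen, 5-chloro-3-methylpyridin-2-yl in place of 5-fluoropyridin-2-yl gives the first step beyond the scatter in this assay, with a 2.9-fold higher number from compound 2 to compound 3 (0.46 log units; beyond the scatter), so this position can move the read-out by more than the scatter, if only modestly. Among these compounds, the same group in place of 3-chloropyridin-2-yl gives a 1.7-fold higher number from compound 1 to compound 3 (0.23 log units; within the scatter), which leaves compound 1 and compound 3 unordered and shows that only the pair of compound 2 and compound 3 stands apart. Nothing at hand accounts for the larger step.

The compounds shown do not separate the part of the chloro from that of the methyl in 5-chloro-3-methylpyridin-2-yl. Going by these compounds, how an amine or a methoxy group on this ring would read in this assay also remains open.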